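Replacing the nitro group of compound 2

The source may hold more compounds than are shown below. What is called first, only, known or untested is meant among the compounds shown, and "the series" means these compounds.

Measured compounds:
- compound 1 `COc1ccc(C(O)(c2cc3cc([N+](=O)[O-])cc(-c4ccccc4)c3o2)c2cncn2C)cc1` gives 4970 nM in a functional assay on QG-56 cells (Homo sapiens) for antiproliferative activity; a higher number here means a weaker inhibitor, a lower number a stronger inhibitor
- compound 2 `Cn1cncc1C(O)(c1ccc(Cl)cc1)c1cc2cc([N+](=O)[O-])cc(-c3ccccc3)c2o1` gives 1890 nM in this assay

Compound 2 holds the lower of the two numbers. Compound 3 `Cn1cncc1C(O)(c1ccc(Cl)cc1)c1cc2cc(C(=O)NN3CCOCC3)cc(-c3ccccc3)c2o1` carries (morpholin-4-yl)carbamoyl in place of nitro on an aromatic carbon. For the measured compounds named here, the only measured step (a 2.6-fold lower number from compound 1 to compound 2 (0.42 log units; beyond the scatter)) is modest and concerns chloro in place of methoxy, at another place, so it sets no direction for this change. No step beyond the scatter is therefore expected in this assay, though with wide uncertainty. Compound 3 is expected at 2000 nM (estimated range 500 nM to 8000 nM). This is the expected step (a 1.1-fold higher number from compound 2 to compound 3 (0.02 log units; within the scatter)).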

Compound 3, half-maximal inhibitory concentration: 73.6 nM
Estimate against measurement, compound 3: 27-fold (1.43 log units) above; the measured number lies below the stated range.
By their numbers in this assay, from the lowest: compound 3; then compound 2; then compound 1.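

On this aromatic carbon of the shared core, the nitro group is not required for activity in this assay: (morpholin-4-yl)carbamoyl in its place gives a 26-fold lower number from compound 2 to compound 3 (1.41 log units; beyond the scatter). For the compounds shown here, the earlier step concerned only the chloro and methoxy place, so this is the first sign that the present position strongly moves the number. No measured evidence bears on the reason for this step.

A primary carboxamide, a carboxylic acid or a (piperidin-1-yl)carbamoyl group here would help separate the contributions of the morpholine ring and the carbonyl-bearing linker. As far as these compounds go, whether the step holds with methoxy in place of chloro also remains open.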